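The source may report more compounds than this note shows. Statements on the series, on what has been measured and on what is new or still open speak of the compounds shown alone.

Measured so far in a functional assay on MCF7 cells (Homo sapiens) for antiproliferative activity, read by MTT assay, with a stated time of 72 h; on this read-out lower numbers stand for stronger inhibition and higher numbers for weaker inhibition:
- compound 1 `CCCNC(=O)c1cc(Oc2ccc(NC(=O)c3nn(-c4ccc(Br)cc4F)c(=O)cc3C)cc2F)ccn1`: "not active" (no number reported)
- compound 2 `CCCNC(=O)c1cc(Oc2ccc(NC(=O)c3nn(-c4ccccc4C)c(=O)cc3C)cc2F)ccn1`: 39600 nM

Among the measured compounds shown here, compound 2 holds the only number, and compound 1 was reported without one, so no ranking can be drawn from these two entries. The next entry is compound 3 `CCCNC(=O)c1cc(Oc2ccc(NC(=O)c3nn(-c4ccccc4OC(F)(F)F)c(=O)cc3C)cc2F)ccn1`, still unmeasured. It carries trifluoromethoxy in place of methyl on an aromatic carbon, ortho to a large group, turning 2-methylphenyl into 2-(trifluoromethoxy)phenyl: trifluoromethoxy in place of methyl on an aromatic carbon. For the measured compounds named here, no measured step speaks to this change, and the only numerical anchor is compound 2 at 39600 nM. No step beyond the scatter is therefore expected in this assay, and no direction is favoured with any confidence. The expected change is a 1.1-fold lower number from compound 2 to compound 3 (0.05 log units; within the scatter). A report without a number also remains possible. For compound 3 the estimated value is 35000 nM, with an expected range of 12000 nM to 90000 nM.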

Compound 3, half-maximal inhibitory concentration: 7420 nM
Compound 3: middle estimate off by 4.7-fold (0.67 log units), on the high side, and the stated range ends above it.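

In this assay, the aromatic carbon ortho to a large group proves sensitive to its substituent: trifluoromethoxy in place of methyl gives a 5.3-fold lower number from compound 2 to compound 3 (0.73 log units; beyond the scatter). Among the compounds shown here, this is the first step that can be read, and it shows that the change from 2-methylphenyl to 2-(trifluoromethoxy)phenyl moves the number beyond the scatter, towards stronger inhibition. Nothing on hand gives a reason for this step.

For the compounds shown here, only two groups with numbers can be compared at this place, and compound 1, reported without a number, gives no step that can be read. As far as these compounds go, whether methoxy, chlorine or an amine at the same place would match trifluoromethoxy or fall back towards methyl remains open, as does whether the step carries over to other substituents on the core.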